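The source may report more compounds than this note shows. Statements on the series, on what has been measured and on what is new or still open speak of the compounds shown alone.

For the measured compounds named here, compound 1, `COc1ccc(Cn2c(=O)n(C3OC(CO)[C@@H](O)[C@H]3O)c3nc(N)nc(O)c32)cc1`, and compound 2, `C=CCn1c(=S)n(COCCO)c2nc(N)nc(O)c21`, are the two measured members of this set. In a functional assay on the whole organism with Mus musculus as the target (a lower number here means a smaller maximal response, a higher number a larger maximal response), compound 1 gives 14%, and compound 2 gives 7%. The number for compound 1 stands highest of the two shown, but its gap to compound 2 lies within the usual scatter, so the two compounds cannot be told apart on this reading. Both maximal responses are small.

Compound 3, `CN(C)CCCn1c(=O)n(C2OC(CO)[C@@H](O)[C@H]2O)c2nc(N)nc(O)c21`, has not yet been measured. It differs from compound 1 in one place: 2-(dimethylamino)ethyl in place of 4-methoxyphenyl on a saturated chain carbon bound to an aromatic nitrogen. The 4-methoxyphenyl with its one six-membered aromatic ring of carbon only leaves, and the 2-(dimethylamino)ethyl with no ring enters on a saturated chain carbon bound to an aromatic nitrogen.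

Going by the values given here, no step between measured compounds is known, and nothing among the measured pair shows how such an exchange moves the maximal response. Since the two known values sit close together and low, the step from compound 1 to compound 3 is expected to be small, a number 2 percentage points lower from compound 1 to compound 3 (within the scatter), with no direction beyond the scatter. For compound 3 a maximal response of 12% is estimated, between 3% and 30%.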

Compound 3, largest response reached (reported as maximal response), in percent of the reference or control that the assay uses: 63%
Compound 3: middle estimate off by 51 percentage points, on the low side; the measured number lies above the stated range.
By their numbers in this assay, from the lowest: compounds 2 and 1 (each within the scatter of the next); then compound 3.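

On the saturated chain carbon bound to an aromatic nitrogen, putting 2-(dimethylamino)ethyl in place of 4-methoxyphenyl gives a number 49 percentage points higher from compound 1 to compound 3 (beyond the scatter) in this assay. For the compounds shown here, this shows that the maximal response can change strongly at this position, which the earlier pair, with both readings low and no step between them, could not show. Nothing shown explains this rise.

The compounds shown leave open whether the rise follows from the loss of the 4-methoxybenzyl group or from the arrival of the dimethylamino end of the 3-(dimethylamino)propyl chain, a question that a plain propyl chain at this place could address. They also leave open how much the end group matters, as a primary amine or a morpholine there would show, and whether a shorter or longer chain would give a similar response.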